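The source may hold more compounds than are shown below. What is called first, only, known or untested is meant among the compounds shown, and "the series" means these compounds.

Values in a functional assay on HepG2 cells (Homo sapiens) for antiproliferative activity, read by MTT assay, with a stated time of 24 h; a lower number here means a stronger inhibitor, a higher number a weaker inhibitor:
- Compound 1 `COc1cc(OC)c(-c2coc3cc(OCC(=O)c4cccc(C(F)(F)F)c4)ccc3c2=O)cc1OC`: > 10000 nM, a limit of the assay
- Compound 2 `COc1cc(OC)c(-c2coc3cc(OCc4ccccc4F)ccc3c2=O)cc1OC`: 1280 nM
- Compound 3 `COc1cc(OC)c(-c2coc3cc(OCc4ccc([N+](=O)[O-])cc4)ccc3c2=O)cc1OC`: 2500 nM

Compound 3, at 2500 nM, stands level with compound 2, at 1280 nM, as the two lie within the scatter of each other. Compound 4 `COc1cc(OC)c(-c2coc3cc(OCc4ccc(Cl)cc4)ccc3c2=O)cc1OC` carries chloro in place of nitro on an aromatic carbon, para to a large group, so that 4-nitrobenzyl becomes 4-chlorobenzyl (chloro in place of nitro on an aromatic carbon).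

The closest guide is a 2.0-fold higher number from compound 2 to compound 3 (0.29 log units; within the scatter), where 4-nitrophenyl replaces 2-fluorophenyl. The steps of an at least 7.8-fold lower number from compound 1 to compound 2 (0.89 log units; beyond the scatter) and an at least 4.0-fold lower number from compound 1 to compound 3 (0.60 log units; beyond the scatter) are larger, but both remove (3-(trifluoromethyl)phenyl)carbonyl, a different change, and both start from a limit. They bear only weakly on this comparison. On the evidence of compound 2 and compound 3, no change beyond the scatter is expected in this assay, and the expected step is a 1.3-fold lower number from compound 3 to compound 4 (0.10 log units; within the scatter). For compound 4 the estimated value is 2000 nM, with an expected range of 700 nM to 6000 nM.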

Compound 4, half-maximal inhibitory concentration: 940 nM
Compound 4: middle estimate off by 2.1-fold (0.33 log units), on the high side; measured number inside the range.
By their numbers in this assay, from the lowest: compounds 4, 2 and 3 (each within the scatter of the next, the first and the last beyond it). At a limit, above all of these: compound 1.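

In this assay, for the compounds shown here, chloro in place of nitro on this aromatic carbon gives a 2.7-fold lower number from compound 3 to compound 4 (0.42 log units; beyond the scatter), the first step beyond the scatter that does not start from compound 1, so a change at this one carbon can shift the number on its own. The other two readings are a 1.4-fold lower number from compound 2 to compound 4 (0.13 log units; within the scatter), which leaves the 4-chlorophenyl and 2-fluorophenyl groups level, and an at least 10-fold lower number from compound 1 to compound 4 (1.02 log units; beyond the scatter), the widest step in the set. The value of compound 1 is a limit, so this last step gives only a minimum: the limit of > 10000 nM in this assay, at which 1 of the 4 values shown sits.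

Open, on these data alone, is how an amine or a carboxylic acid on this same carbon would read in this assay. Also open is whether chloro would hold its number elsewhere on the ring, and the compounds shown give no reason for the gap between chloro and nitro.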